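Hydroxy for trifluoromethyl on the extended urea series

The source may report more compounds than this note shows. Statements on the series, on what has been measured and on what is new or still open speak of the compounds shown alone.

compound 1 `COc1cc(NC(C)CCCNC(=O)Nc2cccc(F)c2)c2ncccc2c1` gives 18000 nM
compound 2 `COc1cc(NC(C)CCCNC(=O)Nc2cccc(O)c2)c2ncccc2c1` gives 48000 nM
compound 3 `COc1cc(NC(C)CCCNC(=O)NNC(=O)Nc2cccc(C(F)(F)F)c2)c2ncccc2c1` gives 4900 nM

In a functional assay on HeLa cells (Homo sapiens) for inhibition, read by MTT assay, with a stated time of 72 h (on this read-out higher numbers stand for weaker inhibition and lower numbers for stronger inhibition), compound 3 has the lowest of the three numbers, at 4900 nM. Compound 4 `COc1cc(NC(C)CCCNC(=O)NNC(=O)Nc2ccc(O)cc2)c2ncccc2c1` is not yet measured. It carries 4-hydroxyphenyl in place of 3-(trifluoromethyl)phenyl on an amide-type nitrogen. Within the data shown here, one measured step bears on this change, a modest one with hydroxy in place of fluoro on an aromatic carbon: a 2.7-fold higher number from compound 1 to compound 2 (0.43 log units; beyond the scatter). Among the measured compounds shown here, that pair has a different linking chain from compound 3, and no measured step removes trifluoromethyl, so the transfer is uncertain. A step of similar size and direction is expected in this assay: a 3.1-fold higher number from compound 3 to compound 4 (0.49 log units; beyond the scatter). Compound 4 is estimated at 15000 nM, with an expected range of 6000 nM to 40000 nM.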

Compound 4, half-maximal inhibitory concentration: 85000 nM
Compound 4: the middle estimate sits 5.7-fold (0.75 log units) below what was measured, and the stated range ends below it.
By their numbers in this assay, from the lowest: compound 3; then compound 1; then compounds 2 and 4 (each within the scatter of the next).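

In this assay, exchanging 3-(trifluoromethyl)phenyl for 4-hydroxyphenyl on an amide-type nitrogen is a large loss on the extended urea, with a 17-fold higher number from compound 3 to compound 4 (1.24 log units; beyond the scatter), so the hydroxy-for-fluoro step on the plain urea understated this change. Set against the plain ureas, the extended 4-hydroxyphenyl compound shows a 1.8-fold higher number from compound 2 to compound 4 (0.25 log units; within the scatter) and a 4.7-fold higher number from compound 1 to compound 4 (0.67 log units; beyond the scatter), so the extended chain keeps no advantage once trifluoromethyl is gone. No evidence in hand accounts for the size of this loss.

The change alters both the group and its place on the ring, and the compounds shown do not separate the two. From the compounds shown here alone, whether 3-hydroxyphenyl, or an amine or methoxy on the same phenyl, would hold the number of compound 3 stays open.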